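The compounds below may be only part of what the source reports. "The series", "measured", "known", "first", "only" and "open" are said of these compounds alone.

The measured compounds:
compound 1, `CCCCCC1(O)C(=O)Nc2ccc(Nc3ccc(OC)cc3)cc21`: 8000 nM
compound 2, `CCCCCCC1(O)C(=O)Nc2ccc(Nc3ccc(OC)cc3)cc21`: 18600 nM

In a functional assay on A549 cells (Homo sapiens) for antiproliferative activity, read by MTT assay, with a stated time of 48 h (on this read-out lower numbers stand for stronger inhibition and higher numbers for weaker inhibition), compound 2 gives 18600 nM and stands highest of the two numbers. Among the compounds with values here, the one measured step, a 2.3-fold higher number from compound 1 to compound 2 (0.37 log units; beyond the scatter), concerns only the length of the saturated chain and is modest in size.

Compound 3, `CCCCCCC1(O)C(=O)Nc2ccc(Nc3ccc(F)cc3)cc21`, is not yet measured. It differs from compound 2 in one place: fluoro in place of methoxy on an aromatic carbon. Within the data shown here, this change sits on the outer aromatic ring, far from the chain, so the single measured step does not bear on it, and no measured pair shows what exchanging methoxy for fluoro there does. With nothing to pull the number either way, the expected change is none beyond the scatter, and the estimate is a step of a 1.0-fold lower number from compound 2 to compound 3 (0.01 log units; within the scatter) from compound 2. Compound 3 is therefore expected to give about 18000 nM in this assay, within a range of 6000 nM to 50000 nM.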

Compound 3, half-maximal inhibitory concentration: 12000 nM
Estimate against measurement, compound 3: 1.5-fold (0.18 log units) above, within the range that was stated.
By their numbers in this assay, from the lowest: compounds 1, 3 and 2 (each within the scatter of the next, the first and the last beyond it).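

In this assay, exchanging 4-methoxyphenyl for 4-fluorophenyl gives a 1.6-fold lower number from compound 2 to compound 3 (0.19 log units; within the scatter), so at this position on the outer ring, the change cannot be told apart from the ordinary variation between repeated measurements. The earlier step concerned only the saturated chain, whereas this one shows that, with the chain of compound 2 in place, methoxy, with its oxygen and carbon, can give way to a single fluorine with no clear change in the number. Nothing available explains this result or shows what either group does in the cells.

Going by these compounds, it remains open how a carboxylic acid, an amine or a nitrile would read at this same ring position. On these data alone, it is also open whether fluoro would behave in the same way alongside the shorter chain of compound 1 or a longer chain.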